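From 4-fluorobenzyl to 2-fluorobenzyl: compound 3 to compound 4

The compounds below may be only part of what the source reports. "The series", "measured", "known", "first", "only" and "open" are said of these compounds alone.

compound 1 `COc1ccc(/C=C2\CN(C(=S)SCc3cn(Cc4ccccc4F)nn3)C/C(=C\c3ccc(OC)cc3)C2=O)cc1` gives > 100000 nM (a limit of the assay)
compound 2 `Cc1ccc(/C=C2\CN(Cc3cn(Cc4ccc(F)cc4)nn3)C/C(=C\c3ccc(C)cc3)C2=O)cc1` gives 26800 nM
compound 3 `Cc1ccc(/C=C2\CN(C(=S)SCc3cn(Cc4ccc(F)cc4)nn3)C/C(=C\c3ccc(C)cc3)C2=O)cc1` gives 45600 nM
compound 4 `Cc1ccc(/C=C2\CN(C(=S)SCc3cn(Cc4ccccc4F)nn3)C/C(=C\c3ccc(C)cc3)C2=O)cc1` not yet measured

Among the measured compounds shown here, all values come from a functional assay on MDA-MB-231 cells (Homo sapiens) for cytotoxicity, read by MTT assay, with a stated time of 24 h (on this read-out higher numbers stand for weaker inhibition and lower numbers for stronger inhibition), and no two measured compounds here differ in one place only. For the measured compounds named here, compound 3 at 45600 nM and compound 2 at 26800 nM lie within the scatter of each other, and these are the only two numbers available. Compound 1 reports only a limit (> 100000 nM) and not a number.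

The next compound, compound 4, has 2-fluorophenyl in place of 4-fluorophenyl on a saturated chain carbon bound to an aromatic nitrogen. The size of this change has not been measured directly in the series, so the expectation is loose. Compound 1 also carries 2-fluorobenzyl, and its value (> 100000 nM) is a limit, which leaves some chance that compound 4 also reports only a limit. The expected step (a 1.2-fold higher number from compound 3 to compound 4 (0.08 log units; within the scatter)) stays within the scatter, with only a slight lean towards a higher number. Compound 4 is estimated at 55000 nM (expected range 25000 nM to 100000 nM).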

Compound 4, half-maximal inhibitory concentration: 91500 nM
Estimate against measurement, compound 4: 1.7-fold (0.22 log units) below, within the range that was stated.
By their numbers in this assay, from the lowest: compounds 2, 3 and 4 (each within the scatter of the next, the first and the last beyond it). At a limit, above all of these: compound 1.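

In this assay, the series now has its first comparison of compounds that differ in one place, 2-fluorophenyl in place of 4-fluorophenyl on a saturated chain carbon bound to an aromatic nitrogen, and it reads a 2.0-fold higher number from compound 3 to compound 4 (0.30 log units; within the scatter). The two fluorophenyl groups therefore cannot be told apart at this position in this assay, and this single pair gives no basis for a preference between them. Compound 1 reports only a limit and not a number, so any compound with a true value beyond that limit would give no measurable step in this read-out: the limit of > 100000 nM in this assay, at which 1 of the 4 values shown sits.

Among the compounds shown here, whether any group at this position can move the number beyond the scatter remains open, as the only substituent change compared here is between two fluorophenyl groups; an unsubstituted phenyl, or a longer chain ending in an amine or a carboxylic acid, would be a more demanding test of the position. Also open, going by these compounds, is whether the series holds any value well below that of compound 2, at 26800 nM.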